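A bromo on the phenyl of compound 1

A few compounds are considered here, and "the series" means these few. Any claim that something is new, unique, unknown or untested is made for them only; others in the source may bear on it.

Compound 1 `COc1cc(NCc2ccccc2)cc(OC)c1OC` was tested in a functional assay on KYSE-450 cells (Homo sapiens) for inhibition, read by MTT assay, with a stated time of 48 h (a lower number here means a stronger inhibitor, a higher number a weaker inhibitor), and gave > 80000 nM, which is a limit of the assay and not a number. Compound 1 thus stands at the limit of > 80000 nM in this assay, at which 1 of the 3 values shown sits. The two other compounds tested gave numbers. Compound 2 `COc1ccc(CN(C(=O)C(C)Br)c2cc(OC)c(OC)c(OC)c2)cc1O` reads 160 nM. Compound 3 `C/C=C/C(=O)N(Cc1ccc(OC)c(OC)c1)c1cc(OC)c(OC)c(OC)c1` reads 39100 nM. Going by the values given here, neither of these values speaks directly to the change considered here, since no measured pair isolates it.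

The next compound to be read is compound 4 `COc1cc(NCc2ccc(Br)cc2)cc(OC)c1OC`, which departs from compound 1 in a single place: bromo in place of hydrogen on an aromatic carbon. In plain terms, a bromo replaces hydrogen on an aromatic carbon, para to a large group, turning phenyl into 4-bromophenyl. Among the compounds with values here, with no measured step to lean on, only a small step is expected in this assay, toward stronger inhibition if there is any, and possibly none beyond the scatter. Compound 4 may well end up reported as a limit too. In numbers, the expected change is an at least 1.3-fold lower number from compound 1 to compound 4 (0.12 log units; that floor lies within the scatter). Compound 4 is estimated at 60000 nM, with an expected range from 20000 nM to 100000 nM.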

Compound 4, half-maximal inhibitory concentration: > 80000 nM
Compound 4: only a limit was reported (the forecaster's own chance of this, stated with the estimate: 55%); middle value at least 1.3-fold (0.12 log units) from the limit.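

As a limit of the assay and not a number, compound 4 reads > 80000 nM in this assay. Compound 1 stands at the same limit, so no step can be read between compound 1 and compound 4: the limit of > 80000 nM in this assay, at which 2 of the 4 values shown sit. The compounds shown leave open whether turning phenyl into 4-bromophenyl changes inhibition at all.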